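Reversing the Methylated Acid Toward a Cyclopropyl Acid

The source may hold more compounds than are shown below. What is called first, only, known or untested is meant among the compounds shown, and "the series" means these compounds.

Compound 3 `CN(C(=O)c1cc(F)cc2cc(-c3ccc(Cl)cc3)oc12)C(C)(C)C(=O)O` stands highest of the three numbers in an assay on isolated protein for inhibition of endoplasmic reticulum aminopeptidase 1 (Homo sapiens), with stated times of 15 min and 20 min (on this read-out higher numbers stand for weaker inhibition and lower numbers for stronger inhibition), at 1970 nM; compound 1 `CC(C)(NC(=O)c1cc(F)cc2cc(-c3ccc(Cl)cc3)oc12)c1nnn[nH]1` gives 275 nM and compound 2 `O=C(NC1(C(=O)O)CCCC1)c1cc(F)cc2cc(-c3ccc(Cl)cc3)oc12` gives 99 nM. Compound 4 `O=C(NC1(C(=O)O)CC1)c1cc(F)cc2cc(-c3ccc(Cl)cc3)oc12` differs from compound 3 in one place: (1-carboxycyclopropyl)amino in place of (1-carboxy-1-methylethyl)(methyl)amino on a carbonyl carbon. The step that bears most directly is a 20-fold higher number from compound 2 to compound 3 (1.30 log units; beyond the scatter), which put (1-carboxy-1-methylethyl)(methyl)amino in place of (1-carboxycyclopentyl)amino; a 7.2-fold higher number from compound 1 to compound 3 (0.86 log units; beyond the scatter) points the same way. Undoing that change, now with a three-membered ring, is expected to give a large drop in this assay for compound 4, a 13-fold lower number from compound 3 to compound 4 (1.12 log units; beyond the scatter). The estimate for compound 4 is 150 nM, within 50 nM to 600 nM.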

Compound 4, half-maximal inhibitory concentration: 1120 nM
Beside the measured number, compound 4's estimate is 7.5-fold (0.87 log units) below it; the whole stated range lies below it.
By their numbers in this assay, from the lowest: compound 2; then compound 1; then compounds 4 and 3 (each within the scatter of the next).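

In this assay, the amide hydrogen and a three-membered ring together bring no recovery at this position on a carbonyl carbon (a 1.8-fold lower number from compound 3 to compound 4 (0.25 log units; within the scatter)). With the amide hydrogen kept, the smaller ring still carries a large cost against the 1-carboxycyclopentyl group (an 11-fold higher number from compound 2 to compound 4 (1.05 log units; beyond the scatter)), and compound 4 also trails the tetrazole (a 4.1-fold higher number from compound 1 to compound 4 (0.61 log units; beyond the scatter)). Nothing available here explains these differences.

The compounds shown leave open where a 1-carboxycyclobutyl group would stand on this ring-size series. They also leave open how the (1-carboxy-1-methylethyl)amino group would compare with its methylated form in compound 3.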